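The compounds below may be only part of what the source reports. "The series", "measured", "known", "first", "only" and "open" are said of these compounds alone.

Compound 1 `CCOC(=O)C1(Cc2ccccc2)CN(c2ccccc2)Cc2nnn(Cc3ccccc3)c21` and compound 2 `CCOC(=O)C1(Cc2ccccc2)CN(c2ccccc2)Cc2nnn(Cc3cccc(F)c3)c21` share one core; compound 3 `CCOC(=O)C1(Cc2ccccc2)CN(c2ccccc2)Cc2nnn(Cc3ccc(Cl)cc3)c21` is still to be measured. In an ADME assay on HEL cells (Homo sapiens) for cytotoxicity, read by microscopy, with a stated time of 3 days (on this read-out higher numbers stand for lower toxicity in this test and lower numbers for higher toxicity in this test), compound 1 gives only a limit of the assay, >= 20000 nM. In this assay compound 2 also gives only a limit, >= 100000 nM. The step that the two limits leave unreadable from compound 1 to compound 2 is the only measured one and cannot be sized, since both values sit at limits (the limit of >= 20000 nM in this assay, at which 1 of the 2 values shown sits, (the limit of >= 100000 nM in this assay, at which 1 of the 2 values shown sits)). Compound 2 thus stands at the higher of the two limits shown. Compound 3 differs by 4-chlorophenyl in place of 3-fluorophenyl on a saturated chain carbon bound to an aromatic nitrogen. With no readable step to draw on, no change beyond the scatter is expected: a number no higher from compound 2 to compound 3 (the limit leaves the size open). Compound 3 is therefore estimated at 100000 nM, within 20000 nM to 200000 nM, most likely reported again as a limit.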

Compound 3, minimum cytotoxic concentration: > 100000 nM
Compound 3 gave a limit, no number; the forecaster's own chance of this, stated with the estimate: 80%; the middle value sits exactly at the limit.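

In this assay, going by these compounds alone, compound 1, compound 2 and compound 3 all give only limits of the assay, and no step among them can be read. Going by these compounds, whether 3-fluorobenzyl or 4-chlorobenzyl changes the minimum cytotoxic concentration at all stays open.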